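Working notes: methyl in place of chloro in compound 2

The source may report more compounds than this note shows. Statements on the series, on what has been measured and on what is new or still open speak of the compounds shown alone.

Measured in a functional assay on K562 cells (Homo sapiens) for antiproliferative activity, read by trypan blue exclusion, with a stated time of 48 h, tested at 10 uM; a higher number here means more inhibition of growth at the concentration tested, a lower number less inhibition of growth:
- compound 1 `Cc1cccc(/C=C/C(=O)Nc2ccc(Cl)cc2C(N)=O)c1`: 37.8%
- compound 2 `NC(=O)c1cc(Br)ccc1NC(=O)/C=C/c1ccccc1Cl`: 59%

Compound 2, at 59%, is the higher of the two, beyond the scatter from compound 1. Compound 3 `Cc1ccccc1/C=C/C(=O)Nc1ccc(Br)cc1C(N)=O` follows from compound 2 with one change: methyl in place of chloro on an aromatic carbon. Among the compounds with values here, no measured pair isolates this change. The methyl-bearing compound 1, at 37.8%, differs from compound 2 in more than one place and offers only weak guidance. A modest fall in this assay is expected, around the edge of the scatter, with an estimated a number 9 percentage points lower from compound 2 to compound 3 (within the scatter). For compound 3 the expected value is 50%, within an estimated range of 33% to 66%.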

Compound 3, percent growth inhibition at one concentration: 43.2%
Compound 3: middle estimate off by 6.8 percentage points, on the high side, within the range that was stated.
By their numbers in this assay, from the lowest: compounds 1 and 3 (each within the scatter of the next); then compound 2.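

Methyl in place of chloro on an aromatic carbon, ortho to a large group, gives a number 15.8 percentage points lower from compound 2 to compound 3 (beyond the scatter) in this assay. Within the data shown here, this is the first step that isolates the change, and it shows that 2-chlorophenyl to 2-methylphenyl is not neutral at this position. No data at hand give a reason for this step.

From the compounds shown here alone, whether a methoxy group, an amine or a carboxylic acid at this position would keep the inhibition of growth seen with chloro remains open. So does whether the step holds at other places on this ring.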